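Aromatic ring versus alkyne on the shared core

A few compounds are considered here, and "the series" means these few. Any claim that something is new, unique, unknown or untested is made for them only; others in the source may bear on it.

Measured so far in a functional assay on CCRF-CEM cells (Homo sapiens), read by MTT assay, with a stated time of 72 h; on this read-out lower numbers stand for stronger inhibition and higher numbers for weaker inhibition:
compound 1 `COc1ncnc2c1c(-c1cccs1)cn2[C@@H]1O[C@H](CO)[C@@H](O)[C@H]1O` gives 90 nM
compound 2 `C#Cc1cn([C@@H]2O[C@H](CO)[C@@H](O)[C@H]2O)c2ncnc(OC)c12` gives > 20000 nM

Compound 2 stands at the weak end of the two numbers shown. Its figure is a limit of the assay rather than a number, (the limit of > 20000 nM in this assay, at which 1 of the 2 values shown sits). For the measured compounds named here, the one measured step, an at least 220-fold higher number from compound 1 to compound 2 (2.34 log units; beyond the scatter), covers the swap on the same aromatic carbon and is the only comparison that bears on the step to compound 3.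

Compound 3 `COc1ncnc2c1c(-c1ccco1)cn2[C@@H]1O[C@H](CO)[C@@H](O)[C@H]1O` is not yet measured. It differs from compound 2 by furan-2-yl in place of ethynyl on an aromatic carbon. The change reverses the direction of the measured step: a five-membered aromatic ring returns to the carbon that in compound 1 carries thiophen-2-yl, and in compound 1 that ring gives 90 nM. Since an at least 220-fold higher number from compound 1 to compound 2 (2.34 log units; beyond the scatter) was large and beyond the scatter, a large step downward is expected in this assay, an at least 100-fold lower number from compound 2 to compound 3 (2.00 log units; beyond the scatter), back toward the range of compound 1, with the uncertainty that the starting point is a limit and that furan-2-yl is not thiophen-2-yl. Compound 3 is estimated at 200 nM, between 40 nM and 2000 nM.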

Compound 3, half-maximal inhibitory concentration: 20 nM
The estimate for compound 3 lay 10-fold (1.00 log units) above the measured number; the whole stated range lies above it.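

With furan-2-yl in place of ethynyl on this aromatic carbon, this assay shows an at least 1000-fold lower number from compound 2 to compound 3 (3.00 log units; beyond the scatter), so the large gap to the ethynyl compound is not confined to thiophen-2-yl and now appears with a second five-membered aromatic ring. As far as these compounds go, the figure for compound 2 is a limit of the assay, so the true size of this step stays unknown: the limit of > 20000 nM in this assay, at which 1 of the 3 values shown sits. The two rings are also distinguished from each other, since furan-2-yl in place of thiophen-2-yl gives a 4.5-fold lower number from compound 1 to compound 3 (0.65 log units; beyond the scatter), a modest step beyond the scatter, which shows that the read-out at this position depends on which five-membered ring is present and not only on whether one is present.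

The compounds shown leave open whether a phenyl ring, a pyridine ring or a saturated ring such as cyclopentyl would fall with compound 3 or with compound 2. Also open, from the compounds shown here alone, is whether a small amine or a short alkyl chain on this carbon would behave like ethynyl, and whether the order of the three groups holds when the rest of the shared core is changed.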